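The compounds below may be only part of what the source reports. "The series", "measured", "known", "first", "only" and "open" are said of these compounds alone.

Measured compounds:
- compound 1 `CN(Cc1ccc(OCCCNC(=N)N)cc1)c1nc2ccc(Oc3ccc(F)cc3)cc2s1`, an assay on SH-SY5Y cells for inhibition of Voltage-dependent N-type calcium channel subunit alpha-1B (Homo sapiens), read by FLIPR and calcium flux, with stated times of 600 s and 300 s, in the presence of a further agent that is not named here; on this read-out lower numbers stand for stronger inhibition and higher numbers for weaker inhibition: 100000 nM
- compound 2 `CN(Cc1ccc(OCCCN)cc1)c1nc2ccc(Oc3ccc(F)cc3)cc2s1`, this assay: 98000 nM
- compound 3 `N=C(N)NCCCOc1ccc(CNc2nc3ccc(Oc4ccc(F)cc4)cc3s2)cc1`, this assay: 244000 nM

Among these three numbers compound 1 stands second highest. Its nearest neighbour is compound 2, reached by a 1.0-fold lower number from compound 1 to compound 2 (0.01 log units; within the scatter), a change on the amine nitrogen of the side chain. Its furthest neighbour is compound 3, reached by a 2.4-fold higher number from compound 1 to compound 3 (0.39 log units; beyond the scatter), a change on the nitrogen on the aromatic ring of the shared core. Compound 4 `CN(Cc1ccc(OCCCNC(=N)N)cc1)c1nc2ccc(Oc3cccc(C(F)(F)F)c3)cc2s1` differs from compound 1 in neither of those places: the change is 3-(trifluoromethyl)phenyl in place of 4-fluorophenyl on an oxygen on an aromatic ring. Going by the values given here, no measured step touches the aryl ether part of the molecule, so neither step speaks directly to this change; the two steps only show that one change left the number where it was and the other moved it modestly. All three measured numbers sit in the same weak region, and compound 4 is therefore expected to stay near compound 1, with no change at the digits printed from compound 1 to compound 4 (within the scatter) as the expected step and no clear direction. The estimate for compound 4 in this assay is 100000 nM, between 30000 nM and 300000 nM.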

Compound 4, half-maximal inhibitory concentration: 202000 nM
Estimate against measurement, compound 4: 2.0-fold (0.31 log units) below; measured number inside the range.
By their numbers in this assay, from the lowest: compounds 2 and 1 (each within the scatter of the next); then compounds 4 and 3 (each within the scatter of the next).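

In this assay, 3-(trifluoromethyl)phenyl in place of 4-fluorophenyl on the oxygen gives a 2.0-fold higher number from compound 1 to compound 4 (0.31 log units; beyond the scatter). Going by these compounds alone, this is the first measured step at the aryl ether part of the molecule, and it shows that a change here can move the number beyond the scatter, modestly and towards weaker inhibition, while it stays in the same weak region. The step changes both the substituent and where it sits on the ring, so it cannot separate the two, and nothing available accounts for the shift.

The compounds shown leave open what a plain phenyl or a cyclohexyl group on the same oxygen would give. They also leave open whether any group at this place can bring the number clearly lower than the values seen so far.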